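Alkyl and benzyl ethers on a shared chloroquinoline-free core

A few compounds are considered here, and "the series" means these few. Any claim that something is new, unique, unknown or untested is made for them only; others in the source may bear on it.

Compound 1, `CCCCCCOc1ccc2c(Cl)ccnc2c1`, gives 2080 nM in a functional assay on NCI-H1650 cells (Homo sapiens) for cytotoxicity, read by MTT assay, with a stated time of 48 h; on this read-out higher numbers stand for weaker inhibition and lower numbers for stronger inhibition.
Compound 2, `CCOc1ccc2c(Cl)ccnc2c1`, gives 3340 nM in this assay.
Compound 3, `Clc1ccnc2cc(OCc3ccccc3)ccc12`, gives 2720 nM in this assay.

Compound 3 stands second highest of the three numbers; its nearest neighbour is compound 2, and the two values lie within the scatter of each other, as do those of compound 3 and compound 1. The step from compound 3 to compound 4, `C=CCOc1ccc2c(Cl)ccnc2c1`, is vinyl in place of phenyl on a saturated chain carbon bound to an oxygen on an aromatic ring. Within the data shown here, two measured steps bear on this place: a 1.3-fold higher number from compound 1 to compound 3 (0.12 log units; within the scatter) and a 1.2-fold lower number from compound 2 to compound 3 (0.09 log units; within the scatter). Both concern the group on the saturated chain carbon bound to the oxygen on the aromatic ring, and neither moved the number beyond the scatter, whether the group entering was a short chain, a longer chain or a ring. A vinyl group in that place is therefore expected to leave the number about where compound 3 sits, with no step beyond the scatter in either direction; the expected step is a 1.0-fold higher number from compound 3 to compound 4 (0.01 log units; within the scatter). For compound 4 the estimated value in this assay is 2800 nM, with a range from 1400 nM to 5600 nM.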

Compound 4, half-maximal inhibitory concentration: 2280 nM
The estimate for compound 4 lay 1.2-fold (0.09 log units) above the measured number; the range from low to high includes it.
By their numbers in this assay, from the lowest: compounds 1, 4, 3 and 2 (each within the scatter of the next).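

Among these compounds, compound 4 puts a double bond outside aromatic rings on the saturated chain carbon bound to an oxygen on an aromatic ring, a kind of group that none of the earlier compounds carries there, and in this assay replacing phenyl with vinyl gives a 1.2-fold lower number from compound 3 to compound 4 (0.08 log units; within the scatter) as its result. Set against the saturated chains, vinyl gives a 1.5-fold lower number from compound 2 to compound 4 (0.17 log units; within the scatter) and a 1.1-fold higher number from compound 1 to compound 4 (0.04 log units; within the scatter), so a short chain, a longer chain, a ring and now a vinyl group all lie within the scatter of one another at this place. Nothing at hand offers a reason for this flat picture.

From the compounds shown here alone, whether an amine or a carboxylic acid on this chain carbon would move the number beyond the scatter remains open. So does the effect of a change elsewhere on the shared core, such as an amine in place of the chlorine.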